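Leaving furan-2-yl for pyridin-4-yl

A few compounds are considered here, and "the series" means these few. Any claim that something is new, unique, unknown or untested is made for them only; others in the source may bear on it.

Three amides on a shared core have been measured in a functional assay on A2780 cells (Homo sapiens) for antiproliferative activity, read by fluorescence, with a stated time of 72 h; a lower number here means a stronger inhibitor, a higher number a weaker inhibitor. There compound 1 `CN1CCC(C(=O)N2Cc3c(NC(=O)c4ccsc4)n[nH]c3C2(C)C)CC1` gives 140 nM and compound 2 `CN1CCC(C(=O)N2Cc3c(NC(=O)c4ccc(Cl)cc4)n[nH]c3C2(C)C)CC1` gives 120 nM. The step between them, a 1.2-fold lower number from compound 1 to compound 2 (0.07 log units; within the scatter), stays within the scatter.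

Compound 3 `CN1CCC(C(=O)N2Cc3c(NC(=O)c4ccco4)n[nH]c3C2(C)C)CC1` reads > 5000 nM, which is a limit of the assay and not a number. It thus stands at the limit of > 5000 nM in this assay, at which 1 of the 3 values shown sits.

Compound 4 `CN1CCC(C(=O)N2Cc3c(NC(=O)c4ccncc4)n[nH]c3C2(C)C)CC1` carries pyridin-4-yl in place of furan-2-yl on a carbonyl carbon.

Going by the values given here, two measured steps bear on this change, since both arrive at the furan-2-yl group: an at least 35-fold higher number from compound 1 to compound 3 (1.55 log units; beyond the scatter) and an at least 41-fold higher number from compound 2 to compound 3 (1.61 log units; beyond the scatter). Both are large, and both groups left behind there gave similar values. Neither step tests pyridin-4-yl, so a return to the level of compound 1 at 140 nM is possible but not assured. A lower number in this assay is expected, beyond the scatter, though perhaps only part of the way back.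

The expected change is an at least 8.3-fold lower number from compound 3 to compound 4 (0.92 log units; beyond the scatter). Compound 4 is estimated at 600 nM, with an expected range of 120 nM to 5000 nM.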

Compound 4, half-maximal inhibitory concentration: 500 nM
Beside the measured number, compound 4's estimate is 1.2-fold (0.08 log units) above it; measured number inside the range.
By their numbers in this assay, from the lowest: compounds 2 and 1 (each within the scatter of the next); then compound 4. At a limit, above all of these: compound 3.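

In this assay the change gives an at least 10-fold lower number from compound 3 to compound 4 (1.00 log units; beyond the scatter), which shows that the loss seen with furan-2-yl does not extend to every aromatic ring with one hetero atom on this carbonyl carbon. On these data alone, compound 3 reads > 5000 nM, a limit of the assay and not a number, so the true size of that step stays unknown, and compound 3 remains alone at that limit: the limit of > 5000 nM in this assay, at which 1 of the 4 values shown sits. Going by these compounds alone, the recovery is only partial, with a 4.2-fold higher number from compound 2 to compound 4 (0.62 log units; beyond the scatter) and a 3.6-fold higher number from compound 1 to compound 4 (0.55 log units; beyond the scatter), so this position now separates three levels where the earlier compounds showed two.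

The compounds shown do not separate ring size from the identity of the hetero atom, since pyridin-4-yl differs from furan-2-yl in both. As far as these compounds go, how thiophen-2-yl, pyridin-3-yl or an unsubstituted phenyl group would read at this position remains open.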